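Chain terminus of a catechol vinyl sulfone: hydroxy to propyl

A few compounds are considered here, and "the series" means these few. Any claim that something is new, unique, unknown or untested is made for them only; others in the source may bear on it.

Three compounds share the core seen in compound 3 `O=S(=O)(/C=C/c1ccc(O)c(O)c1)CCCCCCCCO` and differ only at the far end of the chain on the sulfonyl sulfur. In a functional assay, read by fluorescence and spectrophotometry, with a stated time of 1 h (a lower number here means that less compound is needed, a higher number that more compound is needed for the effect), compound 1 `C=CCCCCCS(=O)(=O)/C=C/c1ccc(O)c(O)c1` gives 7100 nM, compound 2 `CCCCCCS(=O)(=O)/C=C/c1ccc(O)c(O)c1` gives 7300 nM and compound 3 gives 6700 nM. The steps of a 1.0-fold higher number from compound 1 to compound 2 (0.01 log units; within the scatter), a 1.1-fold lower number from compound 1 to compound 3 (0.03 log units; within the scatter) and a 1.1-fold lower number from compound 2 to compound 3 (0.04 log units; within the scatter) are each within the scatter, so compound 3 stands level with both others on these numbers.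

Compound 4 `CCCCCCCCCCCS(=O)(=O)/C=C/c1ccc(O)c(O)c1` arises from compound 3 by propyl in place of hydroxy on a saturated chain carbon, eight bonds along the chain from a sulfonyl sulfur. All three measured steps bear on this change, since each alters the same chain end, and none moved this assay beyond the scatter. The exchange of a hydroxy for a propyl is a somewhat larger change than those, yet nothing measured here points to a direction. Compound 4 is therefore expected at 6800 nM, with a range of 3000 nM to 15000 nM. The expected step is a 1.0-fold higher number from compound 3 to compound 4 (0.01 log units; within the scatter), essentially none beyond the scatter.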

Compound 4, half-maximal effective concentration: 11400 nM
Beside the measured number, compound 4's estimate is 1.7-fold (0.22 log units) below it; measured number inside the range.
By their numbers in this assay, from the lowest: compounds 3, 1, 2 and 4 (each within the scatter of the next).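

In this assay, propyl in place of hydroxy gives a 1.7-fold higher number from compound 3 to compound 4 (0.23 log units; within the scatter), and the other two routes to the same compound give a 1.6-fold higher number from compound 2 to compound 4 (0.19 log units; within the scatter) and a 1.6-fold higher number from compound 1 to compound 4 (0.21 log units; within the scatter). This shows that, on a saturated chain carbon eight bonds along the chain from a sulfonyl sulfur, removing the hydroxy and adding the three carbons of propyl together produce no step beyond the scatter, so all four chain ends stand level on these numbers. No evidence is available to explain the size of these steps.

Because the hydroxy leaves as the propyl enters, the step cannot separate the two parts of the change, and a hydroxy at the end of a chain as long as that of compound 4 would address this. Going by these compounds, it also remains open whether an amine, a carboxylic acid or a longer chain at this end would move the number beyond the scatter.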